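The source may hold more compounds than are shown below. What is called first, only, known or untested is meant among the compounds shown, and "the series" means these compounds.

Compound 1 `NC1=NC2(CCSCC2)N(OCCCOc2cccc(Cl)c2Cl)C(N)=N1` gives 30 nM in a functional assay on HL-60 cells (Homo sapiens) for antiproliferative activity, read by MTT assay, with a stated time of 72 h; a higher number here means a weaker inhibitor, a lower number a stronger inhibitor.
Compound 2 `NC1=NC2(CCSCC2)N(OCCCOc2ccc(Br)cc2)C(N)=N1` gives 350 nM.
Compound 3 `COc1ccc(OCCCON2C(N)=NC(N)=NC23CCSCC3)cc1` gives 500 nM.

Compound 3 has the highest number of the three, but its gap to compound 2, a 1.4-fold higher number from compound 2 to compound 3 (0.15 log units; within the scatter), lies within the scatter, so the two cannot be told apart; only compound 1 stands clearly apart, as a 17-fold higher number from compound 1 to compound 3 (1.22 log units; beyond the scatter) shows. Compound 4 `NC1=NC2(CCSCC2)N(OCCCOc2ccccc2Br)C(N)=N1` has not yet been measured in this assay. It differs from compound 3 by 2-bromophenyl in place of 4-methoxyphenyl on an oxygen on a saturated carbon. Two kinds of measured step bear on this change. The step of a 1.4-fold higher number from compound 2 to compound 3 (0.15 log units; within the scatter) shows that exchanging methoxy for bromo on an aromatic carbon barely moved the number, while a 12-fold higher number from compound 1 to compound 2 (1.07 log units; beyond the scatter) and a 17-fold higher number from compound 1 to compound 3 (1.22 log units; beyond the scatter) show that 2,3-dichlorophenyl gave a far lower number than either 4-bromophenyl or 4-methoxyphenyl. Among the measured compounds shown here, no measured compound carries 2-bromophenyl, so whether it behaves like the halogen-bearing ring of compound 1 or like that of compound 2 is open. A moderate lowering, a 3.8-fold lower number from compound 3 to compound 4 (0.59 log units; beyond the scatter), is therefore expected rather than a large one. The estimate for compound 4 is 130 nM, within a range from 30 nM to 500 nM.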

Compound 4, half-maximal inhibitory concentration: 180 nM
Compound 4: the middle estimate sits 1.4-fold (0.14 log units) below what was measured; low and high end bracket the measured number.
By their numbers in this assay, from the lowest: compound 1; then compounds 4, 2 and 3 (each within the scatter of the next, the first and the last beyond it).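

Placing the bromine as in 2-bromophenyl rather than 4-bromophenyl gives no separable difference, with a 1.9-fold lower number from compound 2 to compound 4 (0.29 log units; within the scatter), so these two rings cannot be told apart here. Compound 4 does separate from a ring carrying methoxy, with a 2.8-fold lower number from compound 3 to compound 4 (0.44 log units; beyond the scatter), yet compound 2 cannot be separated from compound 3, so bromine alone does not set the rings apart, and a single bromine still falls short of 2,3-dichlorophenyl, with a 6.0-fold higher number from compound 1 to compound 4 (0.78 log units; beyond the scatter). Nothing shown explains these differences.

From the compounds shown here alone, whether 2-chlorophenyl or 3-chlorophenyl would sit nearer compound 1 or compound 4 remains open, so the contribution of each chlorine to the low number of compound 1 cannot be divided. Also open, going by these compounds, is how an amine or a carboxylic acid on the ring, or a longer chain before the ring oxygen, would change the number.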